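From Compound 3 to Its Chloro Counterpart, Compound 4

The compounds below may be only part of what the source reports. "The series", "measured", "known", "first", "only" and "open" are said of these compounds alone.

Of the compounds shown here, three have been measured so far in a physicochemical assay for lipophilicity, read by HPLC, in phosphate buffer, measured as octanol-water partition, at pH 7.4, tested at 100 uM (a lower number here means a more polar compound, a higher number a more lipophilic compound), and are set out here.

Compound 1 `CCOc1cc(C)c(-c2cccc(CNc3ccc(OCC(=O)O)c(F)c3)c2)c(C)c1` gives 3.04
Compound 2 `Cc1cc(OCCCS(C)(=O)=O)cc(C)c1-c1cccc(CNc2ccc(OCC(=O)O)c(F)c2)c1` gives 1.73
Compound 3 `O=C(O)COc1ccc(NCc2cccc(-c3ccccc3)c2)cc1F` gives 2.25

Of these three, compound 3 stands second highest, lower than compound 1 and higher than compound 2, and both gaps lie beyond the scatter. Compound 4 `O=C(O)COc1ccc(NCc2ccc(Cl)c(-c3ccccc3)c2)cc1F` has not yet been measured. It carries chloro in place of hydrogen on an aromatic carbon of compound 3, ortho to a phenyl group (chloro in place of hydrogen on an aromatic carbon).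

Among the compounds with values here, only one measured step is available for comparison. That step, (methylsulfonyl)methyl in place of hydrogen on a saturated chain carbon, is a number 1.31 log units lower from compound 1 to compound 2 (beyond the scatter) and involves a different group in a different place. Within the data shown here, it therefore offers only a loose yardstick of size, and no measured step shows what chloro does. A moderate rise, much smaller than that large step, is nevertheless expected for a single added chlorine. The estimated change is a number 0.50 log units higher from compound 3 to compound 4 (beyond the scatter) and this remains an expectation. In this assay the estimate for compound 4 is 2.75 (expected range 2.4 to 3.1).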

Compound 4, distribution coefficient: 2.74
Beside the measured number, compound 4's estimate is 0.01 log units above it, and the stated range covers the measured number.
By their numbers in this assay, from the lowest: compound 2; then compound 3; then compounds 4 and 1 (each within the scatter of the next).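

In this assay, placing chloro on this aromatic carbon, ortho to a phenyl group and para to a large group, leaves the reading a number 0.49 log units higher from compound 3 to compound 4 (beyond the scatter), so this position responds measurably to a single added chlorine. The earlier compounds showed only one step, a number 1.31 log units lower from compound 1 to compound 2 (beyond the scatter), made on a saturated chain carbon with a different group, whereas this is the first step shown on an aromatic carbon and the first shown to go upward. No measurement presented here accounts for the size of this rise.

With hydrogen and chloro the only groups shown at this position, it remains open how a nitrile, an amine or a carboxylic acid on the same aromatic carbon would compare in this assay, in size or in direction. Going by these compounds, it is also open whether chloro at this place would give a similar step on the core of compound 1 or compound 2, which carry further groups on the phenyl ring.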